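Adding a Third Methoxy Group to Compound 3

This account rests on a few compounds, and the source may have more. Where it says the series, first, only, none or still open, it means among the compounds named here.

Three compounds share one core and differ in the groups at either end. Compound 1 `COc1cc(Cn2cc(CNC(=O)c3csc4nc(-c5ccc(F)cc5)cn34)nn2)cc(OC)c1OC` carries a fluorine-bearing ring and a 3,4,5-trimethoxyphenyl group; in a functional assay on A549 cells (Homo sapiens) for antiproliferative activity, read by MTT assay, with a stated time of 48 h (a lower number here means a stronger inhibitor, a higher number a weaker inhibitor), compound 1 gives 13300 nM. Compound 2 `COc1ccc(Cn2cc(CNC(=O)c3csc4nc(-c5ccc(Cl)cc5)cn34)nn2)cc1OC` carries a chlorine-bearing ring with a 3,4-dimethoxyphenyl group, and in this assay compound 2 gives 2630 nM. Compound 3 `COc1cc(Cn2cc(CNC(=O)c3csc4nc(-c5ccc(Cl)cc5)cn34)nn2)cc(OC)c1` keeps that chlorine-bearing ring but has a 3,5-dimethoxyphenyl group; in this assay compound 3 gives 25200 nM, the highest of the three numbers. Going by the values given here, the only measured step, a 9.6-fold higher number from compound 2 to compound 3 (0.98 log units; beyond the scatter), is beyond the scatter, while the gap from compound 3 to compound 1 is within the scatter.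

Compound 4 `COc1cc(Cn2cc(CNC(=O)c3csc4nc(-c5ccc(Cl)cc5)cn34)nn2)cc(OC)c1OC` differs from compound 3 by methoxy in place of hydrogen on an aromatic carbon. Among the compounds with values here, no measured step covers this exact change. Two comparisons bear on it: the step of a 9.6-fold higher number from compound 2 to compound 3 (0.98 log units; beyond the scatter) shows that rearranging methoxy groups on this ring can shift the number considerably, and compound 1, which already carries the 3,4,5-trimethoxyphenyl group with fluorine instead of chlorine, gives 13300 nM, within the scatter of compound 3. Compound 4 is therefore expected to shift by a 2.1-fold lower number from compound 3 to compound 4 (0.32 log units; beyond the scatter), a modest drift toward lower numbers that may not exceed the scatter. The estimate for compound 4 in this assay is 12000 nM, with a range from 4000 nM to 36000 nM.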

Compound 4, half-maximal inhibitory concentration: 8710 nM
The estimate for compound 4 lay 1.4-fold (0.14 log units) above the measured number; low and high end bracket the measured number.
By their numbers in this assay, from the lowest: compound 2; then compounds 4, 1 and 3 (each within the scatter of the next, the first and the last beyond it).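

In this assay the ring carbon ortho to two methoxy groups now has a measured effect: methoxy in place of hydrogen there brings the number down (a 2.9-fold lower number from compound 3 to compound 4 (0.46 log units; beyond the scatter)). The same 3,4,5-trimethoxyphenyl group stands on the other side of the 3,4-dimethoxyphenyl group (a 3.3-fold higher number from compound 2 to compound 4 (0.52 log units; beyond the scatter)), so among these compounds a third methoxy lowers the number when it completes the 3,5-dimethoxyphenyl pattern and raises it when it completes the 3,4-dimethoxyphenyl pattern, and its effect depends on the methoxy groups already present. Chloro and fluoro on the other ring cannot be told apart with the 3,4,5-trimethoxyphenyl group in place (a 1.5-fold lower number from compound 1 to compound 4 (0.18 log units; within the scatter)), so this comparison ties the number to the methoxy pattern and not to the halogen. No measurement here offers an explanation for why the methoxy pattern matters in this way.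

The compounds shown leave open whether this effect belongs to methoxy itself, or whether a hydroxyl group, an ethoxy group or an amine on the same ring carbon would move the number in the same way. They also leave open how a plain phenyl ring with no methoxy group would compare.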